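The source may hold more compounds than are shown below. What is called first, only, known or untested is meant among the compounds shown, and "the series" means these compounds.

In a functional assay on SW480 cells (Homo sapiens) for inhibition (a lower number here means a stronger inhibitor of growth, a higher number a weaker inhibitor of growth), compound 2 `CCc1ccccc1-n1ncc(C(=O)Nc2ccc3ccccc3n2)c1C` gives 9700 nM, the lower of the two numbers seen so far; compound 1 `Cc1c(C(=O)Nc2ccc3ccccc3n2)cnn1-c1ccccc1F` gives 33300 nM. For the measured compounds named here, the only measured step is a 3.4-fold lower number from compound 1 to compound 2 (0.54 log units; beyond the scatter). Compound 3 `Cc1c(C(=O)Nc2ccc3ccccc3n2)cnn1-c1cccc(Cl)c1F` carries 3-chloro-2-fluorophenyl in place of 2-ethylphenyl on an aromatic nitrogen, so the ethyl that set compound 2 apart is gone and a chloro is added beside a returned fluoro. Going by the values given here, because a 3.4-fold lower number from compound 1 to compound 2 (0.54 log units; beyond the scatter) is the one step that bears on this change, compound 3 is expected to move back toward compound 1, a step of a 1.9-fold higher number from compound 2 to compound 3 (0.27 log units; within the scatter). The estimate for compound 3 is 18000 nM, within 5000 nM to 50000 nM.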

Compound 3, concentration for 50% growth inhibition: 9000 nM
Beside the measured number, compound 3's estimate is 2.0-fold (0.30 log units) above it; the range from low to high includes it.
By their numbers in this assay, from the lowest: compounds 3 and 2 (each within the scatter of the next); then compound 1.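

In this assay, chloro in place of hydrogen on an aromatic carbon gives a 3.7-fold lower number from compound 1 to compound 3 (0.57 log units; beyond the scatter), so the fluoro-bearing ring reaches the level of compound 2 without any ethyl. Replacing 2-ethylphenyl with 3-chloro-2-fluorophenyl on the aromatic nitrogen gives a 1.1-fold lower number from compound 2 to compound 3 (0.03 log units; within the scatter), so these two groups cannot be told apart in this growth read-out. Nothing at hand explains either step. Going by these compounds, it remains open whether the chloro would hold this level without the fluoro, and whether a methoxy or trifluoromethyl group on this phenyl ring would change the number.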